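A few compounds are considered here, and "the series" means these few. Any claim that something is new, unique, unknown or untested is made for them only; others in the source may bear on it.

Measured so far:

Compound 1, `CC(C)(C)c1ccc(-c2ccc3c(NCCCNCc4ccco4)ccnc3c2)cc1`: in an ADME assay on HepG2 cells (Homo sapiens) for cytotoxicity, read by luminescence, CellTiter-Glo and ATP content, with a stated time of 72 h (on this read-out lower numbers stand for an effect already at smaller amounts and higher numbers for an effect only at larger amounts of compound), compound 1 gives 3150 nM.
Compound 2, `Clc1ccc(Oc2ccc3c(NCCCNCc4ccco4)ccnc3c2)cc1`: compound 2 gives 7800 nM.
Compound 3, `COc1ccc(F)cc1CNCCCNc1ccnc2cc(Oc3ccc(Cl)cc3)ccc12`: compound 3 gives 4500 nM.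

Compounds 1 and 2 share one core and differ at a single place: 4-(tert-butyl)phenyl in place of 4-chlorophenoxy on an aromatic carbon. That change made a 2.5-fold lower number from compound 2 to compound 1 (0.39 log units; beyond the scatter), a modest step. Compound 3 carries a different change from compound 2, on the chain side: 5-fluoro-2-methoxyphenyl in place of furan-2-yl on a saturated chain carbon bound to an amine nitrogen, and that step, a 1.7-fold lower number from compound 2 to compound 3 (0.24 log units; within the scatter), stays within the usual scatter, so compounds 2 and 3 cannot be told apart on this read-out.

Compound 4, `COc1ccc(F)cc1CNCCCNc1ccnc2cc(-c3ccc(C(C)(C)C)cc3)ccc12`, has not been measured. It differs from compound 3 by 4-(tert-butyl)phenyl in place of 4-chlorophenoxy on an aromatic carbon, the same change as from compound 2 to compound 1, at the same place in the core. Within the data shown here, the only guide to its size is the one earlier step, so the expectation is a step of about a 2.4-fold lower number from compound 3 to compound 4 (0.37 log units; beyond the scatter), resting on a 2.5-fold lower number from compound 2 to compound 1 (0.39 log units; beyond the scatter) measured between compounds 2 and 1. On that basis compound 4 is expected to give about 1900 nM in this assay, most likely between 900 nM and 4500 nM.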

Compound 4, half-maximal effective concentration: 620 nM
Beside the measured number, compound 4's estimate is 3.1-fold (0.49 log units) above it; the whole stated range lies above it.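

The swap to 4-(tert-butyl)phenyl lowers the number on both cores in this assay and here gives a 7.3-fold lower number from compound 3 to compound 4 (0.86 log units; beyond the scatter), but its size does not carry over from one core to the other: the same change on two cores in this assay, a 2.5-fold lower number (0.39 log units; beyond the scatter) from compound 2 to compound 1 and a 7.3-fold lower number (0.86 log units; beyond the scatter) from compound 3 to compound 4, 2.9-fold (0.47 log units) apart, beyond the scatter of two such steps. Seen from the chain side, 5-fluoro-2-methoxyphenyl in place of furan-2-yl gives a 5.1-fold lower number from compound 1 to compound 4 (0.71 log units; beyond the scatter) on the core with 4-(tert-butyl)phenyl, and this differs from the step on the core with 4-chlorophenoxy: the same change on two cores in this assay, a 1.7-fold lower number (0.24 log units; within the scatter) from compound 2 to compound 3 and a 5.1-fold lower number (0.71 log units; beyond the scatter) from compound 1 to compound 4, 2.9-fold (0.47 log units) apart, beyond the scatter of two such steps. So in these four compounds the two changes do not simply add up, and what one change does depends on the group at the other place, though this does not show why, or whether it holds beyond this one set.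

On these data alone, it remains open whether the same dependence would appear with a plain phenyl at the aromatic carbon or with a cyclohexyl on the chain. A longer chain between the two amine nitrogens is also untested in what is shown here, so its effect on either step cannot be told.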